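The source may report more compounds than this note shows. Statements on the series, on what has been measured and on what is new or still open speak of the compounds shown alone.

Compound 1, with the structure `CC(Oc1ccccc1-c1ccncc1)C1=NCCN1`, is one of two compounds tested in a functional assay on CHO cells for agonist activity at Alpha-2B adrenergic receptor (Homo sapiens); on this read-out higher numbers stand for larger maximal responses and lower numbers for smaller maximal responses. In this assay compound 1 gives < 0.3, which is a limit of the assay and not a measured number. Compound 2, with the structure `CC(Oc1ccccc1-c1ccccc1)C1=NCCO1`, gives in this assay < 0.3, again a limit rather than a number. Among the compounds with values here, the picture so far is therefore (the limit of < 0.3 in this assay, at which 2 of the 2 values shown sit), and no step between two measured compounds can be drawn from it. Compound 3, with the structure `CC(Oc1ccccc1-c1ccccc1O)C1=NCCN1`, differs from compound 1 in a single place: 2-hydroxyphenyl in place of pyridin-4-yl on an aromatic carbon. Because (the limit of < 0.3 in this assay, at which 2 of the 2 values shown sit), compound 3 is expected to stay close to where compound 1 stands, with a step from compound 1 to compound 3 of about a number no lower from compound 1 to compound 3 (the limit leaves the size open) in this assay, that is within the scatter. The estimate for compound 3 in this assay is 0.3, between 0.1 and 0.6.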

Compound 3, intrinsic activity: the largest response reached, as a fraction of the reference agonist's: < 0.3
Compound 3: only a limit was reported; the forecaster's own chance of this, stated with the estimate: 50%; the middle value lies on the limit itself.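

In this assay compound 3 gives < 0.3, a limit and not a number, so no step can be read between compound 1 and compound 3: the limit of < 0.3 in this assay, at which 3 of the 3 values shown sit. The compounds shown leave open how large a maximal response each reaches, and whether 2-hydroxyphenyl in place of pyridin-4-yl changes it.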